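Removing one bromo from the benzoxazine of compound 1

The source may report more compounds than this note shows. Statements on the series, on what has been measured and on what is new or still open speak of the compounds shown alone.

Measured in a functional assay on MCF7 cells (Homo sapiens) for inhibition, read by MTT assay, with a stated time of 48 h, tested at 30 ug/mL; a higher number here means more inhibition of growth at the concentration tested, a lower number less inhibition of growth:
compound 1 `O=c1cc(-c2ccccc2)oc2ccc(N3COc4c(Br)cc(Br)cc4C3)cc12` gives 16.1%
compound 2 `O=c1cc(-c2ccccc2)oc2cc(N3COc4c(Br)cccc4C3)ccc12` gives 7.89%
compound 3 `O=c1cc(-c2ccccc2)oc2ccc(N3COc4c(Cl)cc(Cl)cc4C3)cc12` gives 74%

Compound 1 stands second highest of the three numbers in this assay. Its nearest neighbour is compound 2, a number lower by an amount that stays within the usual scatter, so the two cannot be told apart. The furthest is compound 3, a number higher by an amount well beyond the scatter; compound 3 is the only one of the three with clear growth inhibition at the concentration tested.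

Compound 4 `O=c1cc(-c2ccccc2)oc2ccc(N3COc4c(Br)cccc4C3)cc12` has not been measured. It differs from compound 1 by hydrogen in place of bromo on an aromatic carbon; the second bromo and the rest of the shared core remain as in compound 1.

Among the compounds with values here, no step between two measured compounds covers this change, so its size must be guessed. Compound 1 is already a weak inhibitor at 16.1%, and compound 2, which also carries a single bromo on the benzoxazine although attached to the core at a different point, gives 7.89%. Nothing here suggests that losing the bromo raises inhibition, and there is little room for it to fall. The expected step of a number 5.1 percentage points lower from compound 1 to compound 4 (within the scatter) is therefore small, probably within the scatter, and if anything downward. Compound 4 is estimated at 11%, with a range from 2% to 28%.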

Compound 4, percent growth inhibition at one concentration: 71.6%
For compound 4 the middle estimate is 60.6 percentage points below the measured one; measured number outside the range, above it.
By their numbers in this assay, from the lowest: compounds 2 and 1 (each within the scatter of the next); then compounds 4 and 3 (each within the scatter of the next).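

In this assay, hydrogen in place of bromo on this aromatic carbon, meta to a bromo group, is a large change: a number 55.5 percentage points higher from compound 1 to compound 4 (beyond the scatter) in the series. This position therefore has a strong bearing on the read-out, and a single remaining bromo group is compatible with clear growth inhibition, something the low numbers of compound 1 and compound 2 gave no sign of. With one bromo each and a different attachment to the core, compound 2 gives 7.89% and compound 4 gives 71.6% in this assay, while no measurement at hand explains why removing this bromo goes with so much more inhibition.

The compounds shown leave open whether the gain depends on hydrogen itself or only on the absence of bromo at this place, a question that fluoro, methoxy or an amine on the same aromatic carbon would address. Also open, on these data alone, is what hydrogen in place of the remaining bromo would do, and whether the same change behaves alike with the other attachment to the core.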